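This account rests on a few compounds, and the source may have more. Where it says the series, first, only, none or still open, it means among the compounds named here.

Measured so far in an ADME assay on cells for inhibition of cytochrome P450 11B1, mitochondrial (Homo sapiens), read by HTRF; on this read-out higher numbers stand for weaker inhibition and lower numbers for stronger inhibition:

Compound 1, `CC(=O)N[C@@H]1CCCc2c1cncc2N1CCc2cc(Cl)ccc2C1=O`, gives 3920 nM.
Compound 2, `CCC(=O)N[C@@H]1CCCc2c1cncc2N1C(=O)c2ccc(Cl)cc2[C@@H]1C`, gives 414 nM.
Compound 3, `CCC(=O)N[C@@H]1CCCc2c1cncc2N1CCc2cc(Cl)ccc2C1=O`, gives 3330 nM.

Compounds 1 and 3 share a core and differ in one spot only: methyl in place of hydrogen on a saturated chain carbon bound to a carbonyl carbon. That change gave a 1.2-fold lower number from compound 1 to compound 3 (0.07 log units; within the scatter), so the two numbers are not told apart here. Compound 2 carries a different core; the difference between the two cores is not broken down here. What is seen is that compound 2 stands lowest of the three, with compound 3 and compound 1 both well beyond the scatter above it.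

Compound 4, `CCC(=O)N[C@@H]1CCCc2c1cncc2N1C(=O)c2ccc(Cl)cc2[C@@H]1CC`, is not yet measured. It is built from compound 2 by methyl in place of hydrogen on a saturated chain carbon bound to a saturated ring carbon. Within the data shown here, this is the same kind of change as the one from compound 1 to compound 3, but not the same: there the new methyl sits on a saturated chain carbon bound to a carbonyl carbon, here on a saturated chain carbon bound to a saturated ring carbon. Among the measured compounds shown here, the one measured example of this kind of change is flat, so a small step is expected, a 1.1-fold higher number from compound 2 to compound 4 (0.04 log units; within the scatter), resting on a 1.2-fold lower number from compound 1 to compound 3 (0.07 log units; within the scatter). For the measured compounds named here, the different surroundings of the change, and the fact that only one example exists, leave the range wide. Compound 4 is therefore estimated at 450 nM, expected to fall between 150 nM and 1400 nM.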

Compound 4, half-maximal inhibitory concentration: 345 nM
For compound 4 the middle estimate is 1.3-fold (0.12 log units) above the measured one; the range from low to high includes it.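

In this assay, methyl in place of hydrogen on a saturated chain carbon bound to a saturated ring carbon gave a 1.2-fold lower number from compound 2 to compound 4 (0.08 log units; within the scatter), so the two numbers cannot be told apart. Set beside the earlier step, where the new methyl sits on a saturated chain carbon bound to a carbonyl carbon, this change looks equally flat, and the two steps do not differ: the same change on two cores in this assay, a 1.2-fold lower number (0.07 log units; within the scatter) from compound 1 to compound 3 and a 1.2-fold lower number (0.08 log units; within the scatter) from compound 2 to compound 4, 1.0-fold (0.01 log units) apart, within the scatter of two such steps This shows that, in these two pairs, a methyl added in place of hydrogen on a saturated chain carbon left the number within the scatter on both cores, but two pairs are a small base, the new methyl sits in a different setting in each, and nothing here shows that the same would hold on any further core.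

The compounds shown leave open whether a group other than methyl at this place, such as a longer chain, an amine or a carboxylic acid, would stay as flat as the methyl to ethyl step did. They also leave open which part of the difference between the core of compound 2 and the core of compound 3 goes with the clearly lower number of compound 2, since those two differ in more than one place.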